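Moving a trifluoromethoxy group in the sulfone series

A few compounds are considered here, and "the series" means these few. Any claim that something is new, unique, unknown or untested is made for them only; others in the source may bear on it.

Compound 1 `CC(O)(CSc1cccc(OC(F)(F)F)c1)C(=O)Nc1cc(C(F)(F)F)cc(C(F)(F)F)c1` and compound 2 `CC(O)(CSc1ccccc1OC(F)(F)F)C(=O)Nc1cc(C(F)(F)F)cc(C(F)(F)F)c1` share one core, while compound 3 `CC(O)(CS(=O)(=O)c1cccc(OC(F)(F)F)c1)C(=O)Nc1cc(C(F)(F)F)cc(C(F)(F)F)c1` and compound 4 `CC(O)(CS(=O)(=O)c1ccccc1OC(F)(F)F)C(=O)Nc1cc(C(F)(F)F)cc(C(F)(F)F)c1` share another; the difference between the two cores is not broken down here. In a functional assay on CWR22R cells (Homo sapiens) for antiproliferative activity, read by fluorescence and propidium iodide staining, with a stated time of 96 h (on this read-out higher numbers stand for weaker inhibition and lower numbers for stronger inhibition), compound 1 gives 6420 nM and compound 2 gives 2940 nM, a step of a 2.2-fold lower number from compound 1 to compound 2 (0.34 log units; beyond the scatter) by 2-(trifluoromethoxy)phenyl in place of 3-(trifluoromethoxy)phenyl on a sulfur. Compound 3 gives 12800 nM in this assay. The change to compound 4, (2-(trifluoromethoxy)phenyl in place of 3-(trifluoromethoxy)phenyl on a sulfonyl sulfur), is the same kind of change, though the place lines differ: it sits on a sulfonyl sulfur rather than on a sulfur. With a single earlier step to rest on, compound 4 is expected to show a step of a 2.1-fold lower number from compound 3 to compound 4 (0.33 log units; beyond the scatter), close to that seen from compound 1 to compound 2. The estimate for compound 4 in this assay is therefore 6000 nM, within 2800 nM to 13000 nM.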

Compound 4, half-maximal inhibitory concentration: 8990 nM
Compound 4: the middle estimate sits 1.5-fold (0.18 log units) below what was measured, and the stated range covers the measured number.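

On the sulfonyl sulfur, 2-(trifluoromethoxy)phenyl in place of 3-(trifluoromethoxy)phenyl gives a 1.4-fold lower number from compound 3 to compound 4 (0.15 log units; within the scatter) in this assay. Set beside the earlier step on a sulfur, this one does not differ from it, so as far as these two pairs can tell, the change carries from one core to the other: the same change on two cores in this assay, a 2.2-fold lower number (0.34 log units; beyond the scatter) from compound 1 to compound 2 and a 1.4-fold lower number (0.15 log units; within the scatter) from compound 3 to compound 4, 1.5-fold (0.19 log units) apart, within the scatter of two such steps This does not show a real gain on the sulfonyl core, where the step stays within the scatter, and two pairs set no rule for any other core.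

The compounds shown leave open whether the same move holds for a nitrile or a fluorine in place of trifluoromethoxy. They also leave open how it behaves on a core with a sulfinyl group in place of the sulfur.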